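Working notes: benzamido in place of the oxopyrrolidinyl group

The compounds below may be only part of what the source reports. "The series", "measured", "known", "first", "only" and "open" are said of these compounds alone.

Measured so far in a physicochemical assay for lipophilicity, using the shake flask method, in phosphate buffer, measured as octanol-water partition, with a stated time of 30 min, at pH 7.4; a higher number here means a more lipophilic compound, a lower number a more polar compound:
- compound 1 `Cc1nc(CN(C)C)ccc1-c1cnc(NCc2c(F)ccc3c2CCO3)c2cn[nH]c(=O)c12`: 2
- compound 2 `CC1(C)CC(=O)N(c2cnc(NCc3c(F)ccc4c3CCO4)n3cnnc23)C1`: 2

In this assay compound 2 stands level with compound 1, and the two values lie within the scatter of each other. Compound 3 `O=C(Nc1cnc(NCc2c(F)ccc3c2CCO3)n2cnnc12)c1ccccc1` is the next to be read. It carries benzamido in place of 4,4-dimethyl-2-oxopyrrolidin-1-yl on an aromatic carbon. A six-membered aromatic ring of carbon only thus enters, and a five-membered non-aromatic ring leaves.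

Within the data shown here, the series holds no measured step for an exchange of this kind, so the expectation rests on the structural change and on compound 2 at 2. A small upward step is expected, and the estimate is a number 0.40 log units higher from compound 2 to compound 3 (beyond the scatter). For compound 3 the estimated value is 2.4, with an expected range of 1.9 to 3.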

Compound 3, distribution coefficient: 3
The estimate for compound 3 lay 0.60 log units below the measured number; the range from low to high includes it.
By their numbers in this assay, from the lowest: compounds 1 and 2 (each within the scatter of the next); then compound 3.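

Among these compounds, at this position, on an aromatic carbon of the shared core, benzamido in place of 4,4-dimethyl-2-oxopyrrolidin-1-yl gives the first step that can be read in this assay: a number 1.00 log units higher from compound 2 to compound 3 (beyond the scatter). The group at this place therefore moves the read-out beyond the scatter, which a series without any earlier step could not show. Nothing measured in the series accounts for the size or direction of this step.

The exchange changes several things at once, replacing a five-membered non-aromatic ring with a six-membered aromatic ring of carbon only and bringing in a hydrogen-bond donor, so the compounds shown cannot separate these contributions. An acetamido group at the same place, or a carboxylic acid on the benzamido ring, would be needed to tell how far the step depends on the aromatic ring and how far on the amide hydrogen.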